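A few compounds are considered here, and "the series" means these few. Any claim that something is new, unique, unknown or untested is made for them only; others in the source may bear on it.

For the measured compounds named here, compound 3 `COc1ccc(F)cc1CNCCCNc1ccnc2cc(Oc3ccc(C(C)(C)C)cc3)ccc12` gives 7200 nM in an ADME assay on HepG2 cells (Homo sapiens) for cytotoxicity, read by luminescence, CellTiter-Glo and ATP content, with a stated time of 72 h (on this read-out lower numbers stand for an effect already at smaller amounts and higher numbers for an effect only at larger amounts of compound), the highest of the three numbers so far. Compound 1 `COc1ccc(F)cc1CNCCCNc1ccnc2cc(Cc3cc(C)cc(C)c3)ccc12` gives 940 nM and compound 2 `COc1ccc(F)cc1CNCCCNc1ccnc2cc(CC(C)C)ccc12` gives 2900 nM in this assay. All three differ at one aromatic carbon of the shared core, and the steps at that carbon are a 7.7-fold higher number from compound 1 to compound 3 (0.88 log units; beyond the scatter) and a 2.5-fold higher number from compound 2 to compound 3 (0.39 log units; beyond the scatter), with a 3.1-fold higher number from compound 1 to compound 2 (0.49 log units; beyond the scatter) between the other pair, every one of them modest. Compound 4 `COc1ccc(F)cc1CNCCCNc1ccnc2cc(-c3cccc4ccccc34)ccc12` carries naphthalen-1-yl in place of 4-(tert-butyl)phenoxy on an aromatic carbon. Of the measured compounds only compound 1 also bears an aromatic group on this carbon, and its number is the lowest of the set. For compound 4 a downward step of a 2.4-fold lower number from compound 3 to compound 4 (0.38 log units; beyond the scatter) is therefore expected, smaller than the gap to compound 1. The estimate for compound 4 is 3000 nM, with a range from 1000 nM to 9000 nM.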

Compound 4, half-maximal effective concentration: 16000 nM
Compound 4: middle estimate off by 5.3-fold (0.73 log units), on the low side, and the stated range ends below it.
By their numbers in this assay, from the lowest: compound 1; then compound 2; then compound 3; then compound 4.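

In this assay, naphthalen-1-yl on this aromatic carbon gives the highest number of the set, so carrying an aromatic group here does not by itself go with the low number of compound 1, as a 17-fold higher number from compound 1 to compound 4 (1.23 log units; beyond the scatter) shows. For the compounds shown here, this is the only large step, and the number also lies above those with the other two groups, with a 2.2-fold higher number from compound 3 to compound 4 (0.35 log units; beyond the scatter) and a 5.5-fold higher number from compound 2 to compound 4 (0.74 log units; beyond the scatter). No measurement at hand accounts for this order. Open, going by these compounds, is whether the low number of compound 1 depends on the benzyl link or on its two methyl groups, which plain benzyl and phenyl could separate. Also open, on these data alone, is how an amine such as morpholine or a carboxylic acid on this carbon would compare.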